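From a Fluorobenzyl to an Ethyl Group on the Core

A few compounds are considered here, and "the series" means these few. Any claim that something is new, unique, unknown or untested is made for them only; others in the source may bear on it.

Three compounds share one core and differ only in the group on the saturated chain carbon bound to an aromatic nitrogen. Compound 1 `O=C(O)CN1C(=O)/C(=C/c2nc3ccccc3n2Cc2ccc([N+](=O)[O-])cc2)SC1=S` carries a 4-nitrophenyl there, compound 2 `O=C(O)CN1C(=O)/C(=C/c2nc3ccccc3n2Cc2ccc(F)cc2)SC1=S` a 4-fluorophenyl, and compound 3 `O=C(O)CN1C(=O)/C(=C/c2nc3ccccc3n2Cc2ccc(F)c(F)c2)SC1=S` a 3,4-difluorophenyl. In a functional assay on PC-3 cells (Homo sapiens) for cytotoxicity, read by MTT assay, with a stated time of 48 h (on this read-out lower numbers stand for stronger inhibition and higher numbers for weaker inhibition), compound 1 gives 8270 nM, compound 2 gives 4860 nM and compound 3 gives 5970 nM. Compound 2 has the lowest of the three numbers, yet the step of a 1.7-fold lower number from compound 1 to compound 2 (0.23 log units; within the scatter) and the step of a 1.2-fold higher number from compound 2 to compound 3 (0.09 log units; within the scatter) both fall within the scatter, as does a 1.4-fold lower number from compound 1 to compound 3 (0.14 log units; within the scatter), so the three compounds cannot be told apart on these numbers.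

Compound 4 `CCn1c(/C=C2\SC(=S)N(CC(=O)O)C2=O)nc2ccccc21` takes the step from compound 2 in which (methyl in place of 4-fluorophenyl on a saturated chain carbon bound to an aromatic nitrogen). The measured steps all exchange one substituent on the aromatic ring for another; none removes the ring itself, so they bear only loosely on this change, and each of them stayed within the scatter. The account therefore expects no large shift, leaning toward a somewhat higher number, a 1.6-fold higher number from compound 2 to compound 4 (0.22 log units; within the scatter). Compound 4 is estimated at 8000 nM, with an expected range from 3000 nM to 25000 nM.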

Compound 4, half-maximal inhibitory concentration: 3250 nM
Beside the measured number, compound 4's estimate is 2.5-fold (0.39 log units) above it, and the stated range covers the measured number.
By their numbers in this assay, from the lowest: compounds 4, 2, 3 and 1 (each within the scatter of the next, the first and the last beyond it).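

Among these compounds, exchanging the whole 4-fluorobenzyl group for ethyl removes the aromatic ring itself, which none of the earlier steps did, and in this assay this gives a 1.5-fold lower number from compound 2 to compound 4 (0.17 log units; within the scatter) and a 1.8-fold lower number from compound 3 to compound 4 (0.26 log units; within the scatter). Among the compounds shown here, only a 2.5-fold lower number from compound 1 to compound 4 (0.41 log units; beyond the scatter) passes the scatter, modestly, and it is the first step in this set to do so, which shows that an aromatic ring at this position is not required for numbers of this size. Nothing at hand bears on why these steps take the sizes they do.

The compounds shown leave open how a longer chain such as propyl or butyl would read at this position. They also leave open whether an amine or a hydroxyl group carried on that chain would give a step beyond the scatter.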